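Cytotoxicity notes: methylsulfanyl for benzyloxy on the shared core

The source may report more compounds than this note shows. Statements on the series, on what has been measured and on what is new or still open speak of the compounds shown alone.

Compound 1 `Nc1nc(OCc2ccccc2)c2ncn(/C=C3/CC3(CO)CO)c2n1`: > 20000 nM
Compound 2 `CCCNc1nc(N)nc2c1ncn2/C=C1/CC1(CO)CO`: "not determined" (no result reported)

In an ADME assay on MOLT-3 cells (Homo sapiens) for cytotoxicity, with a stated time of 7 days (on this read-out higher numbers stand for lower toxicity in this test and lower numbers for higher toxicity in this test), compound 1 reaches only the limit of the test, > 20000 nM, so no single number is known for it. For compound 2 this assay reports "not determined" (no result reported). Thus the limit of > 20000 nM in this assay, at which 1 of the 2 values shown sits, is the only evidence on the shared core. Compound 3 `CSc1nc(N)nc2c1ncn2/C=C1/CC1(CO)CO` is not yet measured; it differs from compound 1 by methylsulfanyl in place of benzyloxy on an aromatic carbon. Within the data shown here, with no measured step to rest on, the expected change a step that the limit leaves unreadable from compound 1 to compound 3 is none beyond the scatter. Compound 3 is therefore expected at 40000 nM, in the range 15000 nM to 100000 nM, most likely again as a limit.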

Compound 3, half-maximal cytotoxic concentration: > 20000 nM
Compound 3 was reported as a limit (the forecaster's own chance of this, stated with the estimate: 80%); the middle value is on the limit's open side.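

In this assay, no step can be read between compound 1 and compound 3, as both are reported only as limits: the limit of > 20000 nM in this assay, at which 2 of the 3 values shown sit.

Going by these compounds, whether methylsulfanyl in place of benzyloxy changes cytotoxicity at all remains open.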